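Swapping an aminoethoxy group for chloro on an MNK1 inhibitor

This account rests on a few compounds, and the source may have more. Where it says the series, first, only, none or still open, it means among the compounds named here.

Measured compounds:
- Compound 1, `NC(=O)c1ccc(-c2cccnc2)cc1OC1CCNC1`: 1900 nM
- Compound 2, `NCCOc1cc(-c2cccnc2)ccc1C(N)=O`: 820 nM

Both numbers come from an assay on cells for inhibition of MAP kinase-interacting serine/threonine-protein kinase 1 (Homo sapiens), read by mobility shift assay, with stated times of 10 min and 60 min, in the presence of a further agent that is not named here; a lower number here means a stronger inhibitor, a higher number a weaker inhibitor. For the measured compounds named here, compound 2 holds the lower of the two numbers; its only neighbour is compound 1, and the step of a 2.3-fold lower number from compound 1 to compound 2 (0.36 log units; beyond the scatter) is a modest one that lies beyond the scatter.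

Compound 3, `NC(=O)c1ccc(-c2cccnc2)cc1Cl`, has not yet been measured. It differs from compound 2 in one place: chloro in place of 2-aminoethoxy on an aromatic carbon.

Going by the values given here, only one measured step exists, and it bears on this change only loosely: the step from compound 1 to compound 2 swapped one amine-bearing group for another on the same oxygen, while here the whole 2-aminoethoxy group, with its hydrogen-bond donor and acceptors, is removed and a single chlorine atom put in its place. Among the compounds with values here, with no measured pair showing what losing that group does, the expectation rests on the fact that the two measured compounds both carry an amine there. Compound 3 is therefore expected to give a somewhat higher number, a step of a 3.7-fold higher number from compound 2 to compound 3 (0.56 log units; beyond the scatter), with wide uncertainty. The estimate for compound 3 is 3000 nM, ranging from 800 nM to 12000 nM.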

Compound 3, half-maximal inhibitory concentration: 11000 nM
For compound 3 the middle estimate is 3.7-fold (0.56 log units) below the measured one; the range from low to high includes it.
By their numbers in this assay, from the lowest: compound 2; then compound 1; then compound 3.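

For the compounds shown here, the position ortho to a carbamoyl group matters far more in this assay than the earlier compounds could show, since they only traded one amine-bearing group for another: chloro in place of 2-aminoethoxy gives a 13-fold higher number from compound 2 to compound 3 (1.13 log units; beyond the scatter), a large step. Chloro in place of (pyrrolidin-3-yl)oxy points the same way, with a 5.8-fold higher number from compound 1 to compound 3 (0.76 log units; beyond the scatter), so among these three compounds both groups that hold an oxygen and an amine give lower numbers than chloro, and none goes against this. Nothing measured here explains the size of these steps.

Because chloro replaces the oxygen and the amine together, these compounds cannot say which of the two carries the difference, and a methoxy group, which keeps the oxygen and has no amine, would help to separate them. Also open, from the compounds shown here alone, is how a longer chain such as 3-aminopropoxy would read at this position, or a chain that ends in a carboxylic acid instead of an amine.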